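A few compounds are considered here, and "the series" means these few. Any claim that something is new, unique, unknown or untested is made for them only; others in the source may bear on it.

In a functional assay on EOL1 cells (Homo sapiens) for inhibition, read by fluorescence, with a stated time of 72 h (on this read-out higher numbers stand for weaker inhibition of growth and lower numbers for stronger inhibition of growth), compound 1 `CCCCCCn1cnc2c(Nc3ccc(Cl)cc3)nc(N[C@H]3CC[C@H](N)CC3)nc21` gives 440 nM, compound 2 `CCCCCCn1cnc2c(Nc3cc(OC)cc(OC)c3)nc(N[C@H]3CC[C@H](N)CC3)nc21` gives 380 nM and compound 3 `CCCCCCn1cnc2c(Nc3cccc(Cl)c3)nc(N[C@H]3CC[C@H](N)CC3)nc21` gives 310 nM. These three values lie within the scatter of one another, so compound 3 cannot be separated from the other two. Compound 4 `CC(C)=CCC/C(C)=C/Cn1cnc2c(Nc3cccc(Cl)c3)nc(N[C@H]3CC[C@H](N)CC3)nc21` keeps the 3-chlorophenyl group of compound 3 but replaces the hexyl chain with 3,7-dimethylocta-2,6-dien-1-yl: 2,6-dimethylhepta-1,5-dien-1-yl in place of pentyl on a saturated chain carbon bound to an aromatic nitrogen.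

The measured steps all change the phenyl group on a nitrogen: a 1.2-fold lower number from compound 1 to compound 2 (0.06 log units; within the scatter), a 1.4-fold lower number from compound 1 to compound 3 (0.15 log units; within the scatter) and a 1.2-fold lower number from compound 2 to compound 3 (0.09 log units; within the scatter). Each is within the scatter, but none alters the chain, so the data contain no direct measure of this change. Among the compounds with values here, they show only that the three compounds with the hexyl chain stay close together. With no evidence for a direction, the expected result is a 1.0-fold lower number from compound 3 to compound 4 (0.01 log units; within the scatter), with no shift beyond the scatter, though with real uncertainty. For compound 4 the estimated value in this assay is 300 nM, with an expected range of 100 nM to 900 nM.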

Compound 4, concentration for 50% growth inhibition: 590 nM
The estimate for compound 4 lay 2.0-fold (0.29 log units) below the measured number; the range from low to high includes it.
By their numbers in this assay, from the lowest: compounds 3, 2, 1 and 4 (each within the scatter of the next).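

Within the data shown here, this is the first step that touches the chain on the aromatic nitrogen rather than the phenyl group, and in this assay it reads a 1.9-fold higher number from compound 3 to compound 4 (0.28 log units; within the scatter). The position therefore accepts 3,7-dimethylocta-2,6-dien-1-yl in place of hexyl, a change from a pentyl piece of 5 carbons to a piece of 9 carbons with 2 double bonds, without a shift beyond the scatter. Nothing available explains this result.

The compounds shown leave open how far this position stays so forgiving, for instance with a shorter chain such as butyl, or with a chain that ends in an amine or a carboxylic acid. They also leave open whether the same chain change gives a similar step when the 3-chlorophenyl group is replaced by 4-chlorophenyl or 3,5-dimethoxyphenyl.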